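This account rests on a few compounds, and the source may have more. Where it says the series, first, only, none or still open, it means among the compounds named here.

Measured so far in a functional assay on HeLa cells (Homo sapiens) for inhibition, read by sulforhodamine B assay; on this read-out higher numbers stand for weaker inhibition and lower numbers for stronger inhibition:
- compound 1 `O=C1C(Nc2ccccc2)=CC(=O)c2c1nc1n2[C@H]2OC[C@@H](O)[C@H]2OC1`: > 8000 nM
- compound 2 `O=C1C(N2CCCCC2)=CC(=O)c2c1nc1n2[C@H]2OC[C@@H](O)[C@H]2OC1`: > 16000 nM

Compound 1 gives > 8000 nM in this assay, which is a limit of the assay and not a number. Compound 2 gives > 16000 nM, likewise a limit and not a number. For the measured compounds named here, the one measured step, a step that the two limits leave unreadable from compound 1 to compound 2, cannot be sized, since both ends sit at limits (the limit of > 8000 nM in this assay, at which 1 of the 2 values shown sits; (the limit of > 16000 nM in this assay, at which 1 of the 2 values shown sits)). Compound 2 therefore stands only at a limit, and the two values shown allow no ordering between compound 1 and compound 2.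

Compound 3 `COc1cccc(NC2=CC(=O)c3c(nc4n3[C@H]3OC[C@@H](O)[C@H]3OC4)C2=O)c1` differs from compound 2 by (3-methoxyphenyl)amino in place of piperidin-1-yl on a double-bonded ring carbon. This returns to an arylamino substituent of the kind present in compound 1, with a methoxy group added on the aromatic ring. Going by the values given here, the only step that bears on it, a step that the two limits leave unreadable from compound 1 to compound 2, is unreadable in size, so no direction beyond the scatter can be derived from it. What can be said is that compound 1, carrying the plain anilino, gave only > 8000 nM, so compound 3 is expected to stay weak as well. Compound 3 is estimated at 12000 nM, with a range of 3000 nM to 40000 nM. The implied step an at least 1.3-fold lower number from compound 2 to compound 3 (0.12 log units; that floor lies within the scatter) is expected to lie within what the limits leave open, with a high chance that only a limit is again reported.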

Compound 3, half-maximal inhibitory concentration: > 8000 nM
Compound 3 ended at the assay's limit (the forecaster's own chance of this, stated with the estimate: 70%); the middle value lies beyond the limit too.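

In this assay compound 3 gives > 8000 nM, a limit of the assay and not a number. For the compounds shown here, no step among compound 1, compound 2 and compound 3 can be read. The compounds shown leave open how these three compare, and whether any substituent at this place on the shared core gives a numerical value.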